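The source may report more compounds than this note shows. Statements on the series, on what has been measured and on what is new or still open speak of the compounds shown alone.

Measured so far in an assay on isolated protein for binding affinity to cysteinyl leukotriene receptor 1 (Cavia porcellus); on this read-out lower numbers stand for stronger inhibition and higher numbers for weaker inhibition:
- compound 1 `O=C(O)c1ccc(COc2cccc(OCc3ccc4ccccc4n3)c2)cc1` gives 90 nM
- compound 2 `c1cc(OCc2ccc(-c3nn[nH]n3)cc2)cc(OCc2ccc3ccccc3n2)c1` gives 10 nM

Compound 2 holds the lowest of the two numbers in this assay; its nearest neighbour is compound 1, reached by a 9.0-fold lower number from compound 1 to compound 2 (0.95 log units; beyond the scatter), a modest step that lies beyond the scatter. Compound 3 `COc1cc(-c2nn[nH]n2)ccc1COc1cccc(OCc2ccc3ccccc3n2)c1` differs from compound 2 in one place: methoxy in place of hydrogen on an aromatic carbon. Within the data shown here, the only step measured here concerns an exchange of the acidic group, from carboxy to the tetrazole, and it says nothing about what a methoxy on the ring of the tetrazole does. Among the measured compounds shown here, no measured pair speaks to this change, so the size and direction of the step in this assay cannot be read from the data. Compound 3 is therefore expected to stay close to compound 2, with a 1.2-fold higher number from compound 2 to compound 3 (0.08 log units; within the scatter) treated as within the scatter and a wide margin on either side. The estimate for compound 3 is 12 nM, in the range 4 nM to 35 nM.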

Compound 3, inhibition constant: 4.3 nM
Compound 3: middle estimate off by 2.8-fold (0.45 log units), on the high side; the measured number falls inside the stated range.
By their numbers in this assay, from the lowest: compound 3; then compound 2; then compound 1.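

In this assay methoxy in place of hydrogen on an aromatic carbon gives a modest gain that lies beyond the scatter (a 2.3-fold lower number from compound 2 to compound 3 (0.37 log units; beyond the scatter)). Among these compounds, the earlier compounds showed only an exchange of carboxy for 2H-tetrazol-5-yl; this is the first measured sign that the ring carrying that group tolerates a further substituent, here ortho to a large group and meta to the 2H-tetrazol-5-yl group. No measurement at hand explains the size or direction of this step. The compounds shown leave open whether a single fluorine, a hydroxy group or a longer chain such as ethoxy would move the number the same way at this position. They also leave open whether methoxy would give a similar step with carboxy in place of the 2H-tetrazol-5-yl group.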